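The source may hold more compounds than are shown below. What is called first, only, known or untested is meant among the compounds shown, and "the series" means these compounds.

In a functional assay on A549 cells (Homo sapiens) for inhibition, read by MTT assay, with a stated time of 24 h (on this read-out lower numbers stand for stronger inhibition of growth and higher numbers for weaker inhibition of growth), compound 1 `COc1cccc(C(=O)n2c(-c3cn(C)c4ccccc34)nc3ccccc32)c1` gives 10200 nM as the second highest of three numbers. Compound 2 `COc1ccc(C(=O)n2c(-c3cn(C)c4ccccc34)nc3ccccc32)cc1OC` gives 3100 nM on the lower side, and compound 3 `Cn1cc(-c2nc3ccccc3n2C(=O)c2ccccc2Br)c2ccccc21` gives 43200 nM on the higher side.

The change to compound 4 `COc1cccc(C(=O)n2c(-c3cn(C)c4ccc(OC)cc34)nc3ccccc32)c1` is methoxy in place of hydrogen on an aromatic carbon and consists of methoxy in place of hydrogen on an aromatic carbon of a six-membered aromatic ring of carbon only, part of a fused or bridged system of two rings.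

The nearest measured precedent is a 3.3-fold lower number from compound 1 to compound 2 (0.52 log units; beyond the scatter) which is also methoxy in place of hydrogen, but on the phenyl group on the carbonyl carbon, so it carries over only loosely. The steps of a 4.2-fold higher number from compound 1 to compound 3 (0.63 log units; beyond the scatter) and a 14-fold higher number from compound 2 to compound 3 (1.14 log units; beyond the scatter) replace the group on the carbonyl carbon, which compound 4 leaves unchanged, and bear on it little. For the measured compounds named here, no measured step touches the fused system.

A step no larger than modest is expected in this assay with a lower number more likely than a higher one. The estimated step is a 1.9-fold lower number from compound 1 to compound 4 (0.27 log units; within the scatter) and remains uncertain in size. For compound 4 the estimated value is 5500 nM with an expected range from 1800 nM to 16000 nM for now.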

Compound 4, concentration for 50% growth inhibition: 4600 nM
The estimate for compound 4 lay 1.2-fold (0.08 log units) above the measured number, within the range that was stated.
By their numbers in this assay, from the lowest: compounds 2 and 4 (each within the scatter of the next); then compound 1; then compound 3.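

In this assay, methoxy in place of hydrogen on the six-membered aromatic ring of carbon only, meta to a fused ring and para to a fused ring, gives a 2.2-fold lower number from compound 1 to compound 4 (0.35 log units; beyond the scatter). For the compounds shown here, this is the first measured change on the fused system, and it shows that this position tolerates methoxy and that the number falls beyond the scatter, in the same direction as the methoxy step on the phenyl group on the carbonyl carbon, a 3.3-fold lower number from compound 1 to compound 2 (0.52 log units; beyond the scatter). Nothing measured on these compounds gives a cause for the step.

Going by these compounds, whether the lower number is particular to methoxy remains open, since ethoxy, hydroxy or a fluorine atom at this position would test that. Also open, on these data alone, is whether methoxy on both the fused system and the phenyl group would add up in a single compound.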